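Swapping Trifluoromethyl for Tetrazolyl on a Benzamide

The source may report more compounds than this note shows. Statements on the series, on what has been measured and on what is new or still open speak of the compounds shown alone.

Compound 1, `COC(=O)c1cccnc1N[C@@H]1CC[C@@H](C)N(C(=O)c2ccccc2-n2nccn2)C1`, in an assay on cells for displacement of a labelled ligand from Orexin receptor type 2 (Homo sapiens); on this read-out higher numbers stand for weaker inhibition and lower numbers for stronger inhibition: 0.4 nM
Compound 2, `Cc1c(C#N)ccnc1O[C@@H]1CC[C@@H](C)N(C(=O)c2ccccc2C(F)(F)F)C1`, in this assay: 3.1 nM

Of the compounds shown here, two have been measured so far. Compound 2 stands at the higher of the two numbers in this assay, meaning it is the weaker binder of the pair; compound 1 sits well below it, and the gap between them lies beyond the usual scatter of repeated measurements. For the measured compounds named here, the two compounds differ in several places at once, so no single step can be drawn between them.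

Compound 3, `Cc1c(C#N)ccnc1O[C@@H]1CC[C@@H](C)N(C(=O)c2ccccc2-n2ncnn2)C1`, is not yet measured. It keeps everything of compound 2 except one group: 2H-tetrazol-2-yl in place of trifluoromethyl on an aromatic carbon. Compound 1 also bears a small aromatic ring on its benzamide rather than trifluoromethyl and sits far lower. Compound 1 differs from compound 3 elsewhere too; that comparison is only a hint, not a measured step. A moderate move toward a lower number is expected: a 2.1-fold lower number from compound 2 to compound 3 (0.32 log units; beyond the scatter), though an outcome within the scatter would not surprise. For compound 3 the estimate in this assay is 1.5 nM, with a range from 0.4 nM to 5 nM.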

Compound 3, inhibition constant: 1.6 nM
The estimate for compound 3 lay 1.1-fold (0.03 log units) below the measured number, and the stated range covers the measured number.
By their numbers in this assay, from the lowest: compound 1; then compounds 3 and 2 (each within the scatter of the next).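

Where 2H-tetrazol-2-yl replaces trifluoromethyl on an aromatic carbon, ortho to a large group, the swap gives a 1.9-fold lower number from compound 2 to compound 3 (0.29 log units; within the scatter) in this assay. For the compounds shown here, this is the first single-place comparison, and it shows that this position can hold two quite different groups with no change beyond the scatter: one has no ring and 0 hydrogen-bond acceptors, while the other has a five-membered aromatic ring with 4 hetero atoms and 4 hydrogen-bond acceptors. No measurement at hand says why the two groups read so alike in this assay.

The compounds shown leave open how other groups at this position, such as an amine, a carboxylic acid or a longer alkyl chain, would read in this assay. They also leave open whether trifluoromethyl in place of the small aromatic ring on the core of compound 1 would likewise stay within the scatter, since a swap on one core need not carry over to another.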